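Notes on the amine substituent series, chemokine receptor antagonism

This account rests on a few compounds, and the source may have more. Where it says the series, first, only, none or still open, it means among the compounds named here.

Measured so far in a functional assay on cells for antagonist activity at C-X-C chemokine receptor type 4 (Homo sapiens), read by fluorescence and calcium flux, with stated times of 25 min and 90 s; on this read-out lower numbers stand for stronger inhibition and higher numbers for weaker inhibition:
compound 1 `O=S1(=O)CCC(CNCCCCN(C[C@H]2Cc3ccccc3CN2)[C@H]2CCCc3cccnc32)CC1`, 17 nM
compound 2 `c1ccc2c(c1)CN[C@@H](CN(CCCCNC1CCCCC1)[C@H]1CCCc3cccnc31)C2`, 75.2 nM
compound 3 `c1ccc2c(c1)CN[C@@H](CN(CCCCNC1CCNCC1)[C@H]1CCCc3cccnc31)C2`, 63.4 nM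

Compound 3 gives the second highest of the three numbers. Compound 2 lies within the scatter of it (a 1.2-fold lower number from compound 2 to compound 3 (0.07 log units; within the scatter)), while compound 1 is clearly apart (a 3.7-fold higher number from compound 1 to compound 3 (0.57 log units; beyond the scatter)). Compound 4 `CC1(C)CCC(NCCCCN(C[C@H]2Cc3ccccc3CN2)[C@H]2CCCc3cccnc32)CC1` carries 4,4-dimethylcyclohexyl in place of piperidin-4-yl on an amine nitrogen. The step that bears on this most directly is the exchange of cyclohexyl for piperidin-4-yl, a 1.2-fold lower number from compound 2 to compound 3 (0.07 log units; within the scatter), which stayed within the scatter, and 4,4-dimethylcyclohexyl is again a six-membered ring of carbon only. For compound 4 no step beyond the scatter is therefore expected in this assay, the estimated step being a 1.1-fold higher number from compound 3 to compound 4 (0.04 log units; within the scatter). Compound 4 is expected at 70 nM, with a range from 30 nM to 160 nM.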

Compound 4, half-maximal inhibitory concentration: 77.6 nM
Compound 4: middle estimate off by 1.1-fold (0.04 log units), on the low side; measured number inside the range.
By their numbers in this assay, from the lowest: compound 1; then compounds 3, 2 and 4 (each within the scatter of the next).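

In this assay, the 4,4-dimethylcyclohexyl group on this amine nitrogen reads level with both cyclohexyl (a 1.0-fold higher number from compound 2 to compound 4 (0.01 log units; within the scatter)) and piperidin-4-yl (a 1.2-fold higher number from compound 3 to compound 4 (0.09 log units; within the scatter)), so neither the two added methyl groups nor the loss of the ring nitrogen separates these compounds. The (1,1-dioxothian-4-yl)methyl group remains the only one set apart (a 4.6-fold higher number from compound 1 to compound 4 (0.66 log units; beyond the scatter)). No measured evidence accounts for that gap.

On these data alone, whether the lower number of compound 1 goes with its dioxothiane ring or with the methylene link to the amine remains open. A cyclohexylmethyl group at this amine nitrogen would separate the two.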